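Benzyl ether versus acetate series: aryl acrylate swap

The source may hold more compounds than are shown below. What is called first, only, known or untested is meant among the compounds shown, and "the series" means these compounds.

Measured compounds in a functional assay on Raji cells (Homo sapiens) for antiproliferative activity, read by MTT assay, with a stated time of 6 days; on this read-out lower numbers stand for stronger inhibition and higher numbers for weaker inhibition:
compound 1, `COc1ccc(/C=C/C(=O)OC[C@@H](OCc2ccccc2)[C@H]2OC(=O)C=C[C@H]2OCc2ccccc2)cc1`, gives 690 nM.
compound 2, `O=C1C=C[C@@H](OCc2ccccc2)[C@@H]([C@@H](COC(=O)/C=C/c2ccc(F)cc2)OCc2ccccc2)O1`, gives 2470 nM.
compound 3, `COc1ccc(/C=C/C(=O)OC[C@@H](OC(C)=O)[C@H]2OC(=O)C=C[C@H]2OC(C)=O)cc1`, gives 10000 nM.

Compound 1 and compound 2 share one core; compound 3 and the unmeasured compound 4, `CC(=O)O[C@@H]1C=CC(=O)O[C@@H]1[C@@H](COC(=O)/C=C/c1ccc(F)cc1)OC(C)=O`, share another. How the two cores differ is not broken down here. Within the first core, the change fluoro in place of methoxy on an aromatic carbon made the step of a 3.6-fold higher number from compound 1 to compound 2 (0.55 log units; beyond the scatter) in this assay. Compound 3 stands highest of the three measured numbers, and its gap to compound 1 is the widest of the set.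

The change planned into the second core, (fluoro in place of methoxy on an aromatic carbon), is the same change as the one already measured: both "place:" descriptions read alike. For the measured compounds named here, it is expected that compound 4 follows the direction seen from compound 1 to compound 2, so the estimated step in this assay is a 3.0-fold higher number from compound 3 to compound 4 (0.48 log units; beyond the scatter), resting on a 3.6-fold higher number from compound 1 to compound 2 (0.55 log units; beyond the scatter) as the only measured instance of this change. Starting from 10000 nM for compound 3, compound 4 is expected to give 30000 nM in this assay, with a plausible range from 10000 nM to 100000 nM.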

Compound 4, half-maximal inhibitory concentration: 2310 nM
For compound 4 the middle estimate is 13-fold (1.11 log units) above the measured one; the measured number lies below the stated range.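

In this assay, fluoro in place of methoxy on an aromatic carbon of the second core gives a 4.3-fold lower number from compound 3 to compound 4 (0.64 log units; beyond the scatter). For the compounds shown here, the change therefore does not carry over in direction between the two cores, and the two steps differ by more than the scatter allows: the same change on two cores in this assay, a 3.6-fold higher number (0.55 log units; beyond the scatter) from compound 1 to compound 2 and a 4.3-fold lower number (0.64 log units; beyond the scatter) from compound 3 to compound 4, 15-fold (1.19 log units) apart, beyond the scatter of two such steps With only one step on each core, this shows that the outcome of the change depends on the core in these four compounds, but not which feature of the cores is responsible or whether the reversal would hold for other aromatic substituents.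

On these data alone, it remains open whether a core carrying one benzyl ether and one acetate would follow the step seen on the first core or the one seen on the second. Also open, as far as these compounds go, is whether chloro, trifluoromethyl or an amine in the same place on the aromatic ring would split between the two cores in the same way.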